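The compounds below may be only part of what the source reports. "The series", "measured", "known", "first", "only" and "open" are said of these compounds alone.

In an ADME assay on liver for metabolic stability, with Liver microsome (Homo sapiens) as the target, read by LC-MS, using microsomes (a lower number here means slower removal, a higher number faster removal of the compound), compound 1 `CC1(C[C@@H](O)C(=O)N2N=CC[C@H]2C(=O)NCc2cc(Cl)ccc2-n2cnnn2)CC1` gives < 12 mL.min-1.g-1, which is a limit of the assay and not a number. Compound 3 `O=C(NCc1cc(Cl)ccc1-n1cnnn1)[C@@H]1C[C@H]2C[C@H]2N1C(=O)[C@H](O)c1ccccc1` also reaches only a limit, < 15 mL.min-1.g-1. Compound 2 `CCCC[C@@H](O)C(=O)N1C[C@H]2C[C@H]2[C@H]1C(=O)NCc1cc(Cl)ccc1-n1cnnn1` is the only one of the three measured compounds with an actual number, 32 mL.min-1.g-1. Compound 1 therefore has no exact value, and any comparison starting from it begins at a limit.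

Compound 4 `COC(C)(C)[C@@H](O)C(=O)N1N=CC[C@H]1C(=O)NCc1cc(Cl)ccc1-n1cnnn1` keeps the core of compound 1 and differs in one place: 1-methoxy-1-methylethyl stands in place of (1-methylcyclopropyl)methyl on a saturated chain carbon bound to a carbonyl carbon and an oxygen on a saturated carbon (1-methoxy-1-methylethyl in place of (1-methylcyclopropyl)methyl on a saturated chain carbon bound to a carbonyl carbon and an oxygen on a saturated carbon). The group that enters has no ring and brings one hydrogen-bond acceptor, while the heavy-atom count stays the same.

For the measured compounds named here, no pair of measured compounds differs in just one place, so this assay offers no direct precedent for this change. The expectation is therefore for no step beyond the scatter, in either direction. This expectation rests on compound 1 and its limit of < 12 mL.min-1.g-1. The estimated step is a step that the limit leaves unreadable from compound 1 to compound 4. For compound 4 the expected value is 10 mL.min-1.g-1, with an estimated range from 5 mL.min-1.g-1 to 22 mL.min-1.g-1.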

Compound 4, intrinsic clearance in microsomes: < 12 mL.min-1.g-1
Compound 4: no number, only a limit; the forecaster's own chance of this, stated with the estimate: 60%; the middle value does not contradict the limit.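

Compound 1 and compound 4 both stand at a limit of this assay and not at a number, so no step can be read between them: the limit of < 12 mL.min-1.g-1 in this assay, at which 2 of the 4 values shown sit.

The compounds shown leave open how fast either compound is actually removed, and whether 1-methoxy-1-methylethyl in place of (1-methylcyclopropyl)methyl changes that removal at all.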